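The compounds below may be only part of what the source reports. "The series", "measured", "known", "first", "only" and "open" are said of these compounds alone.

The measured compounds:
- Compound 1 `CCCCc1[nH]c(=O)c(S(=O)(=O)c2ccc(-c3ccc(F)cc3)cc2)c(O)c1-c1c(OC)cccc1OC`: "not determined" (no result reported)
- Compound 2 `CCCCc1[nH]c(=O)c(S(=O)(=O)c2ccc(-c3ccncc3C)cc2)c(O)c1-c1c(OC)cccc1OC`: 39%
- Compound 3 `CCCCc1[nH]c(=O)c(S(=O)(=O)c2ccc(-c3ccc(F)nc3)cc2)c(O)c1-c1c(OC)cccc1OC`: "not determined" (no result reported)

In an ADME assay on microsomes from liver (Mus musculus) for metabolic stability, using NADPH, with a stated time of 10 min (a lower number here means that less of the compound is left, a higher number that more of the compound is left), compound 2 gives 39%. For compound 3 this assay reports "not determined" (no result reported), and the same holds for compound 1, which gives "not determined" (no result reported). So compound 3 has no number of its own to stand on; the only number in the series comes from compound 2, and compound 3 differs from it in the ring that is attached to the sulfonyl-bearing ring.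

Compound 4 `CCCCc1[nH]c(=O)c(S(=O)(=O)c2ccc(-n3cc(Cl)ccc3=O)cc2)c(O)c1-c1c(OC)cccc1OC` is not yet measured. The change from compound 3 to compound 4 is a group of 8 heavy atoms (5 carbon, 1 nitrogen, 1 oxygen, 1 chlorine; one six-membered aromatic ring with 1 hetero atom) in place of a group of 7 heavy atoms (5 carbon, 1 nitrogen, 1 fluorine; one six-membered aromatic ring with 1 hetero atom), on an aromatic carbon. Among the measured compounds shown here, no measured pair shows the effect of such a change, so nothing here says whether this step raises or lowers the fraction remaining, or leaves it within the scatter.

With compound 2 at 39% as the only anchor, compound 4 is expected to give about 40% in this assay, within a range from 15% to 70%.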

Compound 4, percent of the compound remaining: 64%
Compound 4: the middle estimate sits 24 percentage points below what was measured; low and high end bracket the measured number.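

In this assay the result is a number 25 percentage points higher from compound 2 to compound 4 (beyond the scatter). Among the compounds shown here, this is the first comparison, and it shows that the ring on this aromatic carbon, para to a large group, can shift the fraction remaining while the rest of the molecule stays the same. The step replaces one whole ring with another, so the chlorine and the carbonyl of compound 4 enter together. Steps involving compound 1 or compound 3 cannot be read, and no measurement shown gives a reason for the rise.

On these data alone, it remains open whether the chlorine, the carbonyl or the ring as a whole accounts for the higher number. Also open, as far as these compounds go, is how a morpholine ring or a carboxylic acid on the same carbon would compare.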